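The source may report more compounds than this note shows. Statements on the series, on what has been measured and on what is new or still open speak of the compounds shown alone.

Measured so far in a functional assay on HCT-15 cells (Homo sapiens) for antiproliferative activity; a lower number here means a stronger inhibitor of growth, a higher number a weaker inhibitor of growth:
- compound 1 `c1ccc(-c2cc(-c3cccnc3)nc(-c3ccccn3)c2)cc1`: 40.9 ug/mL
- compound 2 `c1ccc(-c2cc(-c3cccs3)cc(-c3ccccn3)n2)nc1`: 0.11 ug/mL
- compound 3 `c1ccc(-c2cc(-c3cccs3)cc(-c3ccncc3)n2)nc1`: 15.1 ug/mL

Compound 3 holds the middle place of these three numbers, with compound 1 higher and compound 2 lower. The next compound is compound 4 `c1ccc(-c2cc(-c3cccs3)cc(-c3cccnc3)n2)nc1`, not yet measured. It differs from compound 3 as follows: pyridin-3-yl in place of pyridin-4-yl on an aromatic carbon. In words, pyridin-3-yl stands in place of pyridin-4-yl on an aromatic carbon, next to the ring nitrogen.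

For the measured compounds named here, only one measured step bears on this place: a 140-fold higher number from compound 2 to compound 3 (2.14 log units; beyond the scatter), a large step with pyridin-4-yl in place of pyridin-2-yl. It shows that exchanging one pyridinyl group for another here can move the number a long way in this assay. Going by the values given here, no measured compound in this comparison yet shows what pyridin-3-yl does at this place, so a moderate move toward a lower number is expected, with wide uncertainty. The expected change is a 2.5-fold lower number from compound 3 to compound 4 (0.40 log units; beyond the scatter). For compound 4 the estimated value is 6 ug/mL, with an expected range from 0.8 ug/mL to 30 ug/mL.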

Compound 4, concentration for 50% growth inhibition: 56.1 ug/mL
Compound 4: middle estimate off by 9.4-fold (0.97 log units), on the low side; measured number above the stated range.
By their numbers in this assay, from the lowest: compound 2; then compound 3; then compounds 1 and 4 (each within the scatter of the next).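

In this assay, pyridin-3-yl at this place gives no gain over pyridin-4-yl (a 3.7-fold higher number from compound 3 to compound 4 (0.57 log units; beyond the scatter)) and stands still further from pyridin-2-yl (a 510-fold higher number from compound 2 to compound 4 (2.71 log units; beyond the scatter)), so among the three pyridinyl groups compared here, only pyridin-2-yl, in compound 2, gives a low number. With pyridin-3-yl at this place, thiophen-2-yl and phenyl cannot be told apart (a 1.4-fold higher number from compound 1 to compound 4 (0.14 log units; within the scatter)). No measurement shown gives a reason for the gap between the pyridinyl groups.

As far as these compounds go, it remains open whether the low number of compound 2 would hold with phenyl in place of thiophen-2-yl. Also open, from the compounds shown here alone, is what an amine or a carboxylic acid on the pyridin-2-yl group would do to growth inhibition in this assay.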